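From Methyl to Propyl on a Weak Growth Inhibitor

A few compounds are considered here, and "the series" means these few. Any claim that something is new, unique, unknown or untested is made for them only; others in the source may bear on it.

Two hydroxamic acids frame this comparison, compound 1 `Cc1cc(-c2ccc(F)cc2)nn1Cc1ccc(C(=O)NO)cc1` and compound 2 `Cc1cc(-c2ccc(F)cc2)n(Cc2ccc(C(=O)NO)cc2)n1`. In a functional assay on HepG2 cells (Homo sapiens) for antiproliferative activity, read by MTT assay, with a stated time of 96 h (a lower number here means a stronger inhibitor of growth, a higher number a weaker inhibitor of growth), compound 1 gives 30000 nM, while compound 2 gives 3630 nM. Compound 1 therefore holds the higher of the two numbers, and the gap between them lies beyond the usual scatter of repeated measurements.

The next compound to be tested in this assay is compound 3 `CCCc1cc(-c2ccc(F)cc2)nn1Cc1ccc(C(=O)NO)cc1`. It differs from compound 1 in one place: ethyl in place of hydrogen on a saturated chain carbon bound to an aromatic carbon. This is ethyl in place of hydrogen on a saturated chain carbon bound to an aromatic carbon, so methyl becomes propyl.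

Within the data shown here, no measured pair shows what this change does, so the forecast rests on little. Compound 1, at 30000 nM, sits high enough that a modest move toward a lower number seems more likely than a further rise, though the move may barely clear the scatter. The expected change is a 2.1-fold lower number from compound 1 to compound 3 (0.33 log units; beyond the scatter). For compound 3 the estimated value is 14000 nM, with an expected range from 5000 nM to 35000 nM.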

Compound 3, concentration for 50% growth inhibition: 16800 nM
Compound 3: the middle estimate sits 1.2-fold (0.08 log units) below what was measured; the range from low to high includes it.
By their numbers in this assay, from the lowest: compound 2; then compounds 3 and 1 (each within the scatter of the next).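

Among these compounds, at this saturated chain carbon bound to an aromatic carbon, the result gives the first reading of what extending the chain does: ethyl in place of hydrogen, which turns methyl into propyl, gives a 1.8-fold lower number from compound 1 to compound 3 (0.25 log units; within the scatter). In this assay, the two added carbon atoms therefore leave compound 3 indistinguishable from compound 1, so this single pair shows that the position accepts propyl without a change that can be separated from the ordinary variation of the measurement. No measurement offered here accounts for this outcome, whether in terms of the added ethyl or of anything else about compound 3.

Going by these compounds, what remains open is whether this flat reading holds for other groups at the same place, such as a longer chain like hexyl, a cyclopropyl ring, or a chain ending in an amine or a carboxylic acid, any of which might move the number beyond the scatter. On these data alone, it is also open whether the same change from methyl to propyl would behave alike on compound 2, the compound with the lowest number so far.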